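Cytotoxicity limits in the shared-core ether series

A few compounds are considered here, and "the series" means these few. Any claim that something is new, unique, unknown or untested is made for them only; others in the source may bear on it.

Compound 3 `O=c1oc(OCCOCc2ccccc2)nn1-c1ccc(Oc2ccccc2)cc1` is one of three compounds with a reading in a functional assay on RAW264.7 cells (Mus musculus) for cytotoxicity; a lower number here means that less compound is tolerated, a higher number that more compound is tolerated. In this assay compound 3 gives > 100000 nM, which is a limit of the assay and not a number. Compound 1 `CC(C)COc1nn(-c2ccc(Oc3ccccc3)cc2)c(=O)o1` gives > 100000 nM in this assay, also a limit. Compound 2 `CCCCCCOc1nn(-c2ccccc2)c(=O)o1` gives > 100000 nM in this assay, a limit as well. Every reading thus sits at the limit, as the limit of > 100000 nM in this assay, at which 3 of the 3 values shown sit, records, and compound 3 stands with the rest. Going by the values given here, the one single-point step among measured compounds, a step that the two limits leave unreadable from compound 1 to compound 3, cannot be read for size. Compound 4 `CCCCCCOc1nn(-c2ccc(Oc3ccccc3)cc2)c(=O)o1` differs from compound 3 by butyl in place of benzyloxy on a saturated chain carbon, two bonds along the chain from an oxygen on an aromatic ring. Among the compounds with values here, no measured step bears on this change apart from the unreadable one, and compound 2, which carries the same hexyl chain, sits at the limit. Compound 4 is therefore expected to sit at the limit too. The expected step that the limit leaves unreadable from compound 3 to compound 4 is none beyond the scatter. The estimate for compound 4 is 200000 nM, within 80000 nM to 500000 nM.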

Compound 4, half-maximal cytotoxic concentration: > 100000 nM
Compound 4 was reported as a limit (the forecaster's own chance of this, stated with the estimate: 85%); the middle value is on the limit's open side.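

No step from compound 1, compound 2 or compound 3 to compound 4 can be read for size in this assay, because each reading is a limit: the limit of > 100000 nM in this assay, at which 4 of the 4 values shown sit.

The compounds shown leave open at what concentration any of the four would reach the half-maximal cytotoxic effect, and whether the chain or the phenoxy group shifts it.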